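Phenyl at the aromatic carbon: a cytotoxicity step expected

The source may report more compounds than this note shows. Statements on the series, on what has been measured and on what is new or still open speak of the compounds shown alone.

Measured compounds:
Compound 1, `O=C(CCCCC1CCSS1)NCc1cn(CCCOc2ccc3cc(-c4ccc(Cl)cc4)c(=O)oc3c2)nn1`, gives 67.8%.
Compound 2, `O=C(CCCCC1CCSS1)NCc1cn(CCCCCOc2ccc3ccc(=O)oc3c2)nn1`, gives 71.3%.

Both compounds were tested in a functional assay on PC-12 cells (Rattus norvegicus) for cytotoxicity, read by MTT assay, with stated times of 3 h and 2 h, tested at 10 uM; a higher number here means a stronger effect of the compound at the concentration tested, a lower number a weaker effect. Compound 2 gives the higher of the two numbers on paper, but the gap to compound 1 lies within the usual scatter of repeated measurements, so the two compounds cannot be told apart on this evidence and neither can be called the stronger.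

Compound 3, `O=C(CCCCC1CCSS1)NCc1cn(CCCCCOc2ccc3cc(-c4ccccc4)c(=O)oc3c2)nn1`, has not yet been measured. It differs from compound 2 in one place: phenyl in place of hydrogen on an aromatic carbon. Among the compounds with values here, no step between measured compounds is available that would show what such a change does in this assay. The only related observation is that compound 1, which carries an aryl group of its own on the shared core, gives 67.8%, a number within the scatter of what compound 2 gives. The step of a number 3.3 percentage points lower from compound 2 to compound 3 (within the scatter) is therefore expected to be small, with no direction that goes beyond the scatter. For compound 3 the estimated value is 68%, with a range from 56% to 80%.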

Compound 3, a percentage reported as activity, at one concentration (the size of the read-out at that concentration, not a potency): 26.3%
Beside the measured number, compound 3's estimate is 41.7 percentage points above it, outside the stated range (below it).
By their numbers in this assay, from the lowest: compound 3; then compounds 1 and 2 (each within the scatter of the next).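

In this assay, phenyl in place of hydrogen on this aromatic carbon, two atoms from the ring oxygen, gives a number 45 percentage points lower from compound 2 to compound 3 (beyond the scatter) as the result of a single change. Within the data shown here, this is the first step that isolates one place, and it shows that the read-out at the tested concentration is far from indifferent to what this carbon carries, which compounds 1 and 2, differing in more than one place, could not show. No measurement among those shown offers an explanation for a step of this size.

The compounds shown leave open whether this step belongs to the phenyl ring itself or would also follow from a much smaller group on the same carbon, such as methyl or a single fluorine atom. They also leave open how the number would respond to an amine or a carboxylic acid on the phenyl ring, or to a longer chain between the triazole and the ring oxygen side of the core.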